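Removing the propylamino group from the pyrimidine of compound 2

This account rests on a few compounds, and the source may have more. Where it says the series, first, only, none or still open, it means among the compounds named here.

Compound 1 `CCc1cc(NC(=O)Nc2cccc(C(F)(F)F)c2)cc(Cl)c1Oc1cc(NC)ncn1`: <= 10 nM
Compound 2 `CCCNc1cc(Oc2ccc(NC(=O)Nc3cccc(C(F)(F)F)c3)cc2)ncn1`: 32 nM
Compound 3 `CNc1cc(Oc2c(C)cc(NC(=O)Nc3cccc(C(F)(F)F)c3)cc2C)ncn1`: 25 nM

Three ureas sharing the same core have been tested in an assay on isolated protein for inhibition of serine/threonine-protein kinase TNNI3K (Homo sapiens); a higher number here means a weaker inhibitor, a lower number a stronger inhibitor. Compound 1 is reported only as a limit of the assay, at <= 10 nM, which is the limit of <= 10 nM in this assay, at which 1 of the 3 values shown sits. Compound 2 gives 32 nM, and compound 3 gives 25 nM; these two values sit within the usual scatter of one another, so compound 2 cannot be set apart from compound 3 on the numbers shown.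

Compound 4 `O=C(Nc1ccc(Oc2ccncn2)cc1)Nc1cccc(C(F)(F)F)c1` has not yet been measured. It differs from compound 2 in one place: hydrogen in place of propylamino on an aromatic carbon. Every measured compound carries an alkylamino group on that ring, and none is without it, so nothing measured here fixes the size of this step. The account expects compound 4 to be a weaker inhibitor than compound 2, with an estimated step from a 9.4-fold higher number from compound 2 to compound 4 (0.97 log units; beyond the scatter) that goes beyond the scatter. Compound 4 is therefore estimated at 300 nM, within a range from 60 nM to 1500 nM.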

Compound 4, half-maximal inhibitory concentration: 160 nM
For compound 4 the middle estimate is 1.9-fold (0.27 log units) above the measured one; measured number inside the range.
By their numbers in this assay, from the lowest: compounds 3 and 2 (each within the scatter of the next); then compound 4. At a limit, below all of these: compound 1.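

In this assay, within the data shown here, replacing propylamino with hydrogen gives a 5.0-fold higher number from compound 2 to compound 4 (0.70 log units; beyond the scatter), the first direct reading of this position, since every earlier compound carried an alkylamino group there. The step is modest, and compound 4 still gives 160 nM, so the propylamino group improves inhibition, but measurable inhibition does not depend on it. Nothing shown gives a reason for the size of this step.

Compounds 1 and 3 differ from compound 2 in more than one place, so they do not show how the methylamino group they carry compares with propylamino on the core of compound 2. On these data alone, it also remains open whether the gain comes from the amine nitrogen or from the carbon chain, a question that a propyl or a methoxy group on the same aromatic carbon would address.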